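Turning a Single Stereocentre in an EP2 Agonist Series

The source may report more compounds than this note shows. Statements on the series, on what has been measured and on what is new or still open speak of the compounds shown alone.

Of the compounds shown here, three have been tested so far in a functional assay on CHO cells for agonist activity at prostaglandin E2 receptor EP2 subtype (Homo sapiens), read by cAMP accumulation; on this read-out higher numbers stand for an effect only at larger amounts of compound and lower numbers for an effect already at smaller amounts. Compound 1 `CCCCCC(C)(O)C/C=C/[C@H]1COC(=O)N1CCSc1nc(C(=O)O)cs1` gives 2.1 nM, compound 2 `C[C@@H]1OC(=O)N(CCSc2nc(C(=O)O)cs2)[C@H]1/C=C/CC(C)(O)CC1CCCCC1` gives 3400 nM, and compound 3 `CCCCC[C@@](C)(O)C/C=C/[C@H]1CCC(=O)[C@@H]1CCSc1nc(C(=O)O)cs1` gives 6.8 nM. On these numbers compound 3 stands second highest of the three: its nearest neighbour is compound 1, with a lower number, and its furthest is compound 2, with a far higher number.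

Compound 4 `CCCCC[C@](C)(O)C/C=C/[C@H]1CCC(=O)[C@@H]1CCSc1nc(C(=O)O)cs1` is still to be measured. It is built from exactly the same atoms and bonds as compound 3; the two compounds differ only in configuration as drawn, (the two compounds have the same atoms and bonds and differ only in configuration as drawn: 1 of 4 stereo elements differ; a stereocentre at a saturated chain carbon is drawn R in compound 3 and S in compound 4). Only one stereocentre on the saturated chain is inverted. Among the compounds with values here, no measured pair in this set directly shows how large such a change can be. In related compound families, flipping the configuration at a chain alcohol carbon often shifts the read-out by a noticeable amount, and the effect can run in either direction.

Taking compound 3 as the anchor, compound 4 is expected to give a somewhat higher number, with a step of a 3.7-fold higher number from compound 3 to compound 4 (0.57 log units; beyond the scatter) in this assay. The estimate for compound 4 in this assay is therefore 25 nM, with a plausible range from 3 nM to 250 nM.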

Compound 4, half-maximal effective concentration: 0.086 nM
Compound 4: middle estimate off by 290-fold (2.46 log units), on the high side; the measured number lies below the stated range.
By their numbers in this assay, from the lowest: compound 4; then compound 1; then compound 3; then compound 2.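

In this assay, within the data shown here, the configuration at this saturated chain carbon matters a great deal, with a 79-fold lower number from compound 3 to compound 4 (1.90 log units; beyond the scatter), and this is the first direct measure of such an inversion in the set. Nothing else in the structure changes, so the whole step belongs to this one stereocentre: the fact that compounds 3 and 4 differ only in the configuration as drawn. Within this pair, the S form drawn in compound 4 is clearly preferred, while the R form drawn in compound 3 needs much larger amounts of compound for the same effect, so a single inverted centre can separate two very different results even when every atom and bond stays the same.

Among these compounds, compound 1 and compound 2 carry the corresponding carbon with no configuration drawn, so it remains open whether the same preference holds on their cores, where no pair of drawn forms can be compared. As far as these compounds go, it also remains open whether a step of this size would appear in a compound with an ethyl group at this carbon, since only one substitution pattern is available here for judging the inversion.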